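This account rests on a few compounds, and the source may have more. Where it says the series, first, only, none or still open, it means among the compounds named here.

Measured compounds:
Compound 1 `COc1ccc(SCc2ccc(C(=O)Nc3ccccc3N)cc2)cc1`: 45.7%
Compound 2 `Nc1ccccc1NC(=O)c1ccc(CSc2cccc(F)c2)cc1`: 46.9%
Compound 3 `CC(C)(C)c1ccc(SCc2ccc(C(=O)Nc3ccccc3N)cc2)cc1`: 38.6%

In a functional assay on A549 cells (Homo sapiens) for inhibition, read by CCK-8 assay, with a stated time of 72 h, tested at 2 uM (a higher number here means more inhibition of growth at the concentration tested, a lower number less inhibition of growth), compound 3 gives 38.6% and stands within the scatter of both compound 1 and compound 2. Compound 4 `Nc1ccccc1NC(=O)c1ccc(CSc2ccc(Cl)cc2)cc1` is still unmeasured and has chloro in place of tert-butyl on an aromatic carbon at the same place. Among the compounds with values here, two measured steps bear on this: a number 7.1 percentage points lower from compound 1 to compound 3 (within the scatter) with tert-butyl in place of methoxy, and a number 1.2 percentage points higher from compound 1 to compound 2 (within the scatter) with 3-fluorophenyl in place of 4-methoxyphenyl on a sulfur. Both are small, so no change beyond the scatter is expected. The estimate means an expected step of a number 6.4 percentage points higher from compound 3 to compound 4 (within the scatter) and leans slightly upward toward the other two values. Compound 4 is expected to give 45% within an estimated range from 35% to 55% in this assay.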

Compound 4, percent growth inhibition at one concentration: 47.3%
Estimate against measurement, compound 4: 2.3 percentage points below; measured number inside the range.
By their numbers in this assay, from the lowest: compounds 3, 1, 2 and 4 (each within the scatter of the next).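

In this assay, chloro in place of tert-butyl gives a number 8.7 percentage points higher from compound 3 to compound 4 (within the scatter) at this place on the aromatic ring, so a single chlorine and a group of four carbons are not told apart here. Chloro in place of methoxy gives a number 1.6 percentage points higher from compound 1 to compound 4 (within the scatter) and 4-chlorophenyl in place of 3-fluorophenyl on the sulfur gives a number 0.4 percentage points higher from compound 2 to compound 4 (within the scatter) in the same assay, so none of these changes moves the number beyond the scatter. Nothing available explains why these values stay so close.

From the compounds shown here alone, whether an amine, a carboxylic acid or a longer chain at this place would shift the number beyond the scatter remains open. A reading at one concentration also leaves open whether these four compounds would separate across a range of concentrations.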